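The source may hold more compounds than are shown below. What is called first, only, known or untested is meant among the compounds shown, and "the series" means these compounds.

In an ADME assay on MCF7 cells (Homo sapiens) for cytotoxicity, read by MTT assay, with a stated time of 48 h (on this read-out higher numbers stand for weaker inhibition and lower numbers for stronger inhibition), compound 1 `Fc1ccc2c(Cn3ccnc3)c(-c3ccc(Cl)cc3)[nH]c2c1` gives 45000 nM as a true number. Compound 2 `Clc1ccc(-c2[nH]c3cc(Cl)ccc3c2Cn2ccnc2)cc1` reads > 1000000 nM here, which is a limit of the assay and not a number. Going by the values given here, the one measured step is an at least 22-fold higher number from compound 1 to compound 2 (1.34 log units; beyond the scatter) with chloro in place of fluoro on an aromatic carbon, and it was large. Compound 3 `COc1ccc(-c2[nH]c3cc(Cl)ccc3c2Cn2ccnc2)cc1` differs from compound 2 at another place: methoxy in place of chloro on an aromatic carbon turns 4-chlorophenyl to 4-methoxyphenyl, with methoxy in place of chloro. The measured step shows that one small swap can move this read-out far, but it gives only loose guidance here. Compound 2 reads > 1000000 nM only as a limit, so any measurable result for compound 3 is expected to be a lower number, meaning stronger inhibition. The expected change is an at least 6.6-fold lower number from compound 2 to compound 3 (0.82 log units; beyond the scatter) by this estimate, though another limit reading remains possible. Compound 3 is estimated at 150000 nM with an expected range from 30000 nM to 800000 nM as its likely span.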

Compound 3, half-maximal inhibitory concentration: > 1000000 nM
Compound 3 was reported as a limit; the forecaster's own chance of this, stated with the estimate: 30%; at least 6.6-fold (0.82 log units) between middle value and limit.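

Compound 2 and compound 3 both read as limits rather than numbers in this assay, so no step between them can be read: the limit of > 1000000 nM in this assay, at which 2 of the 3 values shown sit.

As far as these compounds go, whether methoxy in place of chloro changes this read-out at all, and in which direction, stays open.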